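The compounds below may be only part of what the source reports. "The series", "measured", "known", "first", "only" and "open" are said of these compounds alone.

Compound 1, `C=C(Br)C(=O)Nc1ccc(C(=O)/C=C/c2ccccc2)cc1`, gives 880 nM.
Compound 2, `C=C(Br)C(=O)Nc1ccc(C(=O)/C=C/c2ccc(OC)cc2)cc1`, gives 900 nM.
Compound 3, `C=C(Br)C(=O)Nc1ccc(C(=O)/C=C/c2cccc(OC)c2)cc1`, gives 1100 nM.

In a functional assay on L1210 cells (Mus musculus) for antiproliferative activity, with a stated time of 48 h (a lower number here means a stronger inhibitor, a higher number a weaker inhibitor), compound 2 stands second highest of the three numbers, with compound 1 nearest a 1.0-fold higher number from compound 1 to compound 2 (0.01 log units; within the scatter) and compound 3 furthest a 1.2-fold higher number from compound 2 to compound 3 (0.09 log units; within the scatter). Compound 4, `C=C(Br)C(=O)Nc1ccc(C(=O)/C=C/c2ccc(N(C)C)cc2)cc1`, differs from compound 2 only in one place: dimethylamino in place of methoxy on an aromatic carbon. Going by the values given here, no measured step exchanges one such group for another at this position; the closest comparisons, a 1.0-fold higher number from compound 1 to compound 2 (0.01 log units; within the scatter) and a 1.3-fold higher number from compound 1 to compound 3 (0.10 log units; within the scatter), each add a methoxy on an aromatic carbon and both stay within the scatter, so changes at this part of the molecule have so far moved the numbers little. For compound 4 the expected step is therefore no change at the digits printed from compound 2 to compound 4 (within the scatter), not beyond the scatter. Compound 4 is expected to give 900 nM, in the range 400 nM to 2000 nM.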

Compound 4, half-maximal inhibitory concentration: 1900 nM
Estimate against measurement, compound 4: 2.1-fold (0.32 log units) below; the range from low to high includes it.
By their numbers in this assay, from the lowest: compounds 1, 2, 3 and 4 (each within the scatter of the next, the first and the last beyond it).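

In this assay this position, which had shown only steps within the scatter, now gives a step beyond it: dimethylamino in place of methoxy gives a 2.1-fold higher number from compound 2 to compound 4 (0.32 log units; beyond the scatter) and dimethylamino in place of hydrogen gives a 2.2-fold higher number from compound 1 to compound 4 (0.33 log units; beyond the scatter) as a similar modest change. The position therefore responds to at least one group, whereas methoxy in place of hydrogen stayed within the scatter. Nothing measured here explains this change.

Still open, going by these compounds, is whether a plain amine or diethylamino at this position would match dimethylamino. A carboxylic acid there is also untested among the compounds shown.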